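The source may hold more compounds than are shown below. What is called first, only, known or untested is meant among the compounds shown, and "the series" means these compounds.

Values so far in a functional assay on HCT-116 cells (Homo sapiens) for inhibition, read by colorimetric assay, with a stated time of 3 days; a higher number here means a weaker inhibitor, a lower number a stronger inhibitor
compound 1 `O=C(CCCCCCNC(=O)C(O)(O)C(F)(F)F)Nc1ccccc1Br` gives 14500 nM
compound 2 `COc1ccc(NC(=O)CCCCCCNC(=O)C(O)(O)C(F)(F)F)cc1` gives 4520 nM
compound 3 `O=C(CCCCCCNC(=O)C(O)(O)C(F)(F)F)Nc1ccc(F)cc1F` gives 18500 nM

Compound 2 has the lowest number of the three, which makes it the strongest inhibitor measured so far. Compound 4 `Cc1ccc(S(=O)(=O)Nc2ccc(NC(=O)CCCCCCNC(=O)C(O)(O)C(F)(F)F)cc2)cc1` keeps the core of compound 2 but carries ((4-methylphenyl)sulfonyl)amino in place of methoxy on an aromatic carbon. The closest evidence comes from swapping the substituted phenyl group on the amide-type nitrogen. Two such swaps gave modest steps (a 3.2-fold lower number from compound 1 to compound 2 (0.51 log units; beyond the scatter); a 4.1-fold higher number from compound 2 to compound 3 (0.61 log units; beyond the scatter)), and a third stayed within the scatter (a 1.3-fold higher number from compound 1 to compound 3 (0.11 log units; within the scatter)). Going by these compounds, none of them adds a group this large, so the direction stays open and no step beyond the scatter can be firmly expected in this assay. The expected step is small (a 1.1-fold lower number from compound 2 to compound 4 (0.05 log units; within the scatter)). The expected value for compound 4 is 4000 nM (estimated range 1000 nM to 16000 nM).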

Compound 4, half-maximal inhibitory concentration: 17200 nM
The estimate for compound 4 lay 4.3-fold (0.63 log units) below the measured number; measured number outside the range, above it.
By their numbers in this assay, from the lowest: compound 2; then compounds 1, 4 and 3 (each within the scatter of the next).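

Placed on an aromatic carbon, para to a large group, ((4-methylphenyl)sulfonyl)amino in place of methoxy gives a 3.8-fold higher number from compound 2 to compound 4 (0.58 log units; beyond the scatter) in this assay. This shows that a much larger group with its own aromatic ring and a hydrogen-bond donor does not improve on methoxy here, yet costs only a modest step. Nothing measured here accounts for this step.

The compounds shown do not separate the contribution of the sulfonyl link from that of the added ring. Going by these compounds, an amine or a hydroxyl group at this position also remains untested against methoxy.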